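A few compounds are considered here, and "the series" means these few. Any claim that something is new, unique, unknown or untested is made for them only; others in the source may bear on it.

Measured so far in a functional assay on HepG2 cells (Homo sapiens) for inhibition, read by MTT assay, with a stated time of 72 h; on this read-out lower numbers stand for stronger inhibition and higher numbers for weaker inhibition:

Compound 1, `Cc1ccccc1-n1cc(COc2cccc(NC(=O)Nc3ccc(Cl)c(C(F)(F)F)c3)c2)nn1`, gives 3440 nM.
Compound 2, `N#Cc1cccc(-n2cc(COc3cccc(NC(=O)Nc4ccc(Cl)c(C(F)(F)F)c4)c3)nn2)c1`, gives 2760 nM.
Compound 3, `O=C(Nc1cccc(OCc2cn(-c3ccccc3Cl)nn2)c1)Nc1ccc(Cl)c(C(F)(F)F)c1`, gives 1960 nM.

Compound 3 has the lowest of the three numbers, but its separation from the others is small: a 1.8-fold lower number from compound 1 to compound 3 (0.24 log units; within the scatter) and a 1.4-fold lower number from compound 2 to compound 3 (0.15 log units; within the scatter), both within the scatter, as is a 1.2-fold lower number from compound 1 to compound 2 (0.10 log units; within the scatter). Compound 4, `O=C(Nc1cccc(OCc2cn(-c3ccc(Br)cc3)nn2)c1)Nc1ccc(Cl)c(C(F)(F)F)c1`, differs from compound 3 in one place: 4-bromophenyl in place of 2-chlorophenyl on an aromatic nitrogen. The two earlier exchanges of the group on that aromatic nitrogen, from compound 1 to compound 2 and from compound 2 to compound 3, both stayed within the scatter, so no step beyond the scatter is expected here either. Compound 4 is expected near 2500 nM, between 1000 nM and 6000 nM. The expected step is a 1.3-fold higher number from compound 3 to compound 4 (0.11 log units; within the scatter), within the scatter.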

Compound 4, half-maximal inhibitory concentration: 2730 nM
Beside the measured number, compound 4's estimate is 1.1-fold (0.04 log units) below it; the measured number falls inside the stated range.
By their numbers in this assay, from the lowest: compounds 3, 4, 2 and 1 (each within the scatter of the next).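

In this assay, 4-bromophenyl on the aromatic nitrogen stays within the scatter of all three earlier groups: a 1.4-fold higher number from compound 3 to compound 4 (0.14 log units; within the scatter), a 1.0-fold lower number from compound 2 to compound 4 (0.00 log units; within the scatter) and a 1.3-fold lower number from compound 1 to compound 4 (0.10 log units; within the scatter). The flat range at this position therefore now extends to a group substituted at its 4-position and carrying bromine, and all four groups remain unseparated. No measurement available here bears on the reason for this.

Open, going by these compounds, is whether a phenyl bearing an amine or a carboxylic acid would give a step beyond the scatter. A longer alkyl chain in place of the phenyl also remains untested in the compounds shown.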